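The source may hold more compounds than are shown below. What is called first, only, known or untested is meant among the compounds shown, and "the series" means these compounds.

Measured so far:
compound 1, `CCOC(=O)c1c(-c2ccc(Cl)cc2)cc(-c2ccccc2)nc1N1CCCCC1`, gives 29.1%;
compound 2, `CCOC(=O)c1c(-c2ccc(Cl)c(Cl)c2)cc(-c2ccccc2)nc1Nc1ccc(C)cc1`, gives 62.1%.

Both numbers come from a functional assay on the whole organism (strain Wister albino) for inhibition, with Rattus norvegicus as the target, read by paw edema, with stated times of 1 h and 2 h, at a dose of 50 mg/kg by the intraperitoneal route; a lower number here means less inhibition, a higher number more inhibition at the dose given (going by the name of the read-out). Compound 1 stands lowest of the two, and its nearest neighbour, compound 2, lies a number of points higher, beyond the usual scatter. Compound 3, `CCOC(=O)c1c(-c2ccc(Cl)cc2)cc(-c2ccccc2)nc1Nc1ccc(OC)cc1`, has not yet been measured in this assay. It differs from compound 1 in one place: (4-methoxyphenyl)amino in place of piperidin-1-yl on an aromatic carbon. Compound 2 also carries an aromatic amine in place of the piperidin-1-yl of compound 1, but it differs from compound 3 elsewhere as well, so no single change between measured compounds accounts for the gap between their values. Because compound 2 gives 62.1%, the step from compound 1 to compound 3 is expected to be upward and beyond the scatter, a number 20.9 percentage points higher from compound 1 to compound 3 (beyond the scatter). The estimate for compound 3 is 50%, with a range from 35% to 65%.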

Compound 3, a percentage reported as inhibition, in the whole organism at one dose (the size of the read-out at that dose, not a potency): 61.1%
Beside the measured number, compound 3's estimate is 11.1 percentage points below it; the range from low to high includes it.
By their numbers in this assay, from the lowest: compound 1; then compounds 3 and 2 (each within the scatter of the next).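

In this assay, replacing piperidin-1-yl with (4-methoxyphenyl)amino on the aromatic carbon next to the ring nitrogen gives a number 32 percentage points higher from compound 1 to compound 3 (beyond the scatter) while the rest of the core stays the same. Going by these compounds alone, this is the first change confined to this one position, and it shows that the group on this carbon can by itself shift the inhibition of paw edema by a large amount at the dose given. Nothing available explains why the exchange has this effect.

The exchange alters the ring and the linking nitrogen together, so the compounds shown leave open which of these parts carries the step; morpholin-4-yl, benzylamino or an open-chain diethylamino group on this carbon would help separate them. On these data alone, the part played by the methoxy group also remains open, and unsubstituted phenylamino or (4-fluorophenyl)amino would address it.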